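Methoxy Added to the Central Ring of Compound 1

This account rests on a few compounds, and the source may have more. Where it says the series, first, only, none or still open, it means among the compounds named here.

Compound 1 `COc1ccc(Sc2ccccc2N2CC(C)N(CC(=O)O)CC2C)cc1` has the second highest of three numbers in an assay for inhibition of sodium- and chloride-dependent glycine transporter 1 (Homo sapiens) (on this read-out higher numbers stand for weaker inhibition and lower numbers for stronger inhibition), where compound 1 gives 580 nM. Its nearest neighbour is compound 2 `COc1ccc(Sc2ccccc2N2C[C@@H](C)N(CC(=O)O)C[C@@H]2C)cc1`, which gives 160 nM; there is a 3.6-fold lower number from compound 1 to compound 2 (0.56 log units; beyond the scatter). Compound 3 `COc1ccc(Sc2ccccc2N2C[C@H](C)N(CC(=O)O)C[C@H]2C)cc1` gives 53000 nM, and there is a 91-fold higher number from compound 1 to compound 3 (1.96 log units; beyond the scatter). Between those two there is a 330-fold higher number from compound 2 to compound 3 (2.52 log units; beyond the scatter). All three measured steps concern only the drawn configuration, as the fact that one of compounds 1 and 2 is drawn with a defined configuration and the other without, at the place where they differ, the fact that one of compounds 1 and 3 is drawn with a defined configuration and the other without, at the place where they differ and the fact that compounds 2 and 3 differ only in the configuration as drawn show. Compound 4 `COc1ccc(Sc2ccc(OC)cc2N2CC(C)N(CC(=O)O)CC2C)cc1` differs from compound 1 by methoxy in place of hydrogen on an aromatic carbon. Among the compounds with values here, none of the measured steps involves such a change, so no step beyond the scatter is expected: no change at the digits printed from compound 1 to compound 4 (within the scatter). Compound 4 is therefore estimated at 580 nM, with a range from 150 nM to 2500 nM.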

Compound 4, half-maximal inhibitory concentration: > 50000 nM
Compound 4 was reported as a limit (the forecaster's own chance of this, stated with the estimate: 5%); middle value at least 86-fold (1.93 log units) away from the limit.
By their numbers in this assay, from the lowest: compound 2; then compound 1; then compound 3.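

In this assay, compound 4 is reported only as a limit, > 50000 nM. Even so, there is an at least 86-fold higher number from compound 1 to compound 4 (1.93 log units; beyond the scatter), and compound 4 is drawn without configuration, as compound 1 is. The earlier steps shown here changed only drawn configuration, whereas this one shows that the number also responds strongly to methoxy on this aromatic carbon, para to the (4-methoxyphenyl)sulfanyl group.

The compounds shown leave open whether a single fluorine atom or a hydroxyl group here would give a similar rise. They also leave open how the two mirror-image forms of compound 4 would compare.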